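This account rests on a few compounds, and the source may have more. Where it says the series, first, only, none or still open, it means among the compounds named here.

Measured so far:
Compound 1 `Cc1ncc([N+](=O)[O-])n1CCSC(=S)N1CCC(OC(=O)C(Cl)Cl)CC1`; in an ADME assay on HeLa cells (Homo sapiens) for cytotoxicity (a lower number here means a stronger inhibitor, a higher number a weaker inhibitor), compound 1 gives > 1000 ug/mL, which is a limit of the assay.
Compound 2 `Cc1ncc([N+](=O)[O-])n1CCSC(=S)N1CCC(OC(=O)CSC(=S)N2CCCC2)CC1`; in this assay compound 2 gives > 1000 ug/mL, a limit.
Compound 3 `Cc1ncc([N+](=O)[O-])n1CCSC(=S)N1CCC(Cc2ccccc2)CC1`; in this assay compound 3 gives > 1000 ug/mL, a limit.

Compound 3 thus stands only at a limit, and the two further values are limits as well, all sitting at the limit of > 1000 ug/mL in this assay, at which 3 of the 3 values shown sit. Compound 4 `Cc1ncc([N+](=O)[O-])n1CCSC(=S)N1CCC(OC(=O)CN2CCCCC2)CC1` differs from compound 3 in one place: (((piperidin-1-yl)methyl)carbonyl)oxy in place of benzyl on a saturated ring carbon. Among the measured compounds shown here, the steps that bear on this change, a step that the two limits leave unreadable from compound 1 to compound 2 and a step that the two limits leave unreadable from compound 1 to compound 3, are both unreadable because of the limit of > 1000 ug/mL in this assay, at which 3 of the 3 values shown sit. For the measured compounds named here, no measured step therefore gives a size, and no step beyond the scatter is expected in this assay. Compound 4 is expected at 1000 ug/mL, between 400 ug/mL and 3000 ug/mL, most probably reported again as a limit. The expected step of a number no higher from compound 3 to compound 4 (the limit leaves the size open) is therefore none beyond the scatter.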

Compound 4, half-maximal inhibitory concentration: 760 ug/mL
Beside the measured number, compound 4's estimate is 1.3-fold (0.12 log units) above it; measured number inside the range.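

In this assay compound 4 gives 760 ug/mL, the only number among the four compounds shown, so this saturated ring carbon now carries a readable value. The steps read as an at least 1.3-fold lower number from compound 3 to compound 4 (0.11 log units; that floor lies within the scatter), an at least 1.3-fold lower number from compound 2 to compound 4 (0.11 log units; that floor lies within the scatter) and an at least 1.3-fold lower number from compound 1 to compound 4 (0.11 log units; that floor lies within the scatter), so none of these changes is shown to go beyond the scatter. Their true sizes cannot be read because the other three compounds stand at a limit: the limit of > 1000 ug/mL in this assay, at which 3 of the 4 values shown sit.

On these data alone, whether a morpholine in place of the piperidine, or a longer chain between the carbonyl and the ring nitrogen, would move the number beyond the scatter stays open.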